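Nitro for methoxy on the benzyl arm of compound 3

A few compounds are considered here, and "the series" means these few. Any claim that something is new, unique, unknown or untested is made for them only; others in the source may bear on it.

The series shares one core carrying a sugar and a varied arm on a saturated chain carbon bound to an aromatic nitrogen. In a functional assay on the whole organism (B cells) with Mus musculus as the target (a higher number here means a larger maximal response, a lower number a smaller maximal response), compound 1 `NCC(O)Cn1c(=O)n(C2OC(CO)[C@@H](O)[C@H]2O)c2nc(N)nc(O)c21` gives 110%, compound 2 `NC(=O)Cn1c(=O)n(C2OC(CO)[C@@H](O)[C@H]2O)c2nc(N)nc(O)c21` gives 32%, and compound 3 `COc1ccc(Cn2c(=O)n(C3OC(CO)[C@@H](O)[C@H]3O)c3nc(N)nc(O)c32)cc1` gives 44%. Compound 3 thus stands second of the three: a number 12 percentage points higher from compound 2 to compound 3 (beyond the scatter), while a number 66 percentage points lower from compound 1 to compound 3 (beyond the scatter); the remaining step, a number 78 percentage points lower from compound 1 to compound 2 (beyond the scatter), is also large.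

Compound 4 `Nc1nc(O)c2c(n1)n(C1OC(CO)[C@@H](O)[C@H]1O)c(=O)n2Cc1ccc([N+](=O)[O-])cc1` is not yet measured. It differs from compound 3 by nitro in place of methoxy on an aromatic carbon. Among the measured compounds shown here, no measured step bears directly on this change: the three steps recorded all exchange the whole arm on the chain carbon, whereas here the benzyl arm is kept and only its substituent is exchanged. The expectation therefore rests on compound 3 alone, and no step beyond the scatter is assumed. Compound 4 is estimated to show 45% in this assay, with a range from 25% to 70%, meaning an expected step of a number 1 percentage points higher from compound 3 to compound 4 (within the scatter).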

Compound 4, largest response reached (reported as maximal response), in percent of the reference or control that the assay uses: 147%
Beside the measured number, compound 4's estimate is 102 percentage points below it; the whole stated range lies below it.
By their numbers in this assay, from the lowest: compound 2; then compound 3; then compound 1; then compound 4.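

With the benzyl arm kept, exchanging only the group on the aromatic carbon moves the response in this assay by a large amount (a number 103 percentage points higher from compound 3 to compound 4 (beyond the scatter)), which the earlier exchanges of the whole arm could not show. The 4-nitrophenyl arm also stands above both the carbamoyl arm (a number 115 percentage points higher from compound 2 to compound 4 (beyond the scatter)) and the 2-amino-1-hydroxyethyl arm (a number 37 percentage points higher from compound 1 to compound 4 (beyond the scatter)), so the lower number of compound 3 does not hold for every arm ending in a benzene ring. Nothing measured here accounts for the difference between methoxy and nitro.

Going by these compounds, whether this large step belongs to nitro alone remains open: an amine, a nitrile or a carboxylic acid on the same aromatic carbon would test that. Also open, on these data alone, is whether the 4-nitrophenyl group keeps this response on a longer chain.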